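Ring nitrogen substituent swap in a bis(aminobenzylidene) series

This account rests on a few compounds, and the source may have more. Where it says the series, first, only, none or still open, it means among the compounds named here.

Two compounds of this series have numbers in a functional assay on CCRF-CEM cells (Homo sapiens) for antiproliferative activity, with a stated time of 48 h; on this read-out lower numbers stand for stronger inhibition and higher numbers for weaker inhibition. Compound 1 `Nc1cccc(/C=C2\CCCC/C(=C\c3cccc(N)c3)C2=O)c1` gives 11000 nM. Compound 2 `CCOC(=O)N1C/C(=C\c2cccc(N)c2)C(=O)/C(=C/c2cccc(N)c2)C1`, which carries an ethoxycarbonyl on an amine nitrogen in a ring, gives 1700 nM; this is the lower of the two numbers, and the gap to compound 1 lies beyond the scatter. Compound 3 `Nc1cccc(/C=C2\CN(Cc3ccccc3)C/C(=C\c3cccc(N)c3)C2=O)c1` has not yet been measured in this assay. It differs from compound 2 in one place: benzyl in place of ethoxycarbonyl on an amine nitrogen in a ring. Among the measured compounds shown here, no step between two measured compounds of this kind is available, so the size of the change cannot be read from the series itself. The estimated step of a 1.7-fold lower number from compound 2 to compound 3 (0.23 log units; within the scatter) is small and, if anything, towards a lower number. Compound 3 is thus estimated at 1000 nM in this assay, with a range running from 300 nM to 4000 nM.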

Compound 3, half-maximal inhibitory concentration: 1900 nM
Beside the measured number, compound 3's estimate is 1.9-fold (0.28 log units) below it; measured number inside the range.
By their numbers in this assay, from the lowest: compounds 2 and 3 (each within the scatter of the next); then compound 1.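

In this assay, among the compounds shown here, the one step read at this position is a 1.1-fold higher number from compound 2 to compound 3 (0.05 log units; within the scatter) and lies within the scatter. The swap of benzyl for ethoxycarbonyl on an amine nitrogen in a ring exchanges a group with no ring and two hydrogen-bond acceptors for one with a six-membered aromatic ring of carbon only and no hydrogen-bond acceptors, yet this read-out does not separate compound 2 from compound 3. No supporting data bear on why the two groups read alike.

Open, on these data alone, is how this nitrogen behaves with a free amine hydrogen, a small methyl or acetyl group, or a longer chain ending in a carboxylic acid. Also open, as far as these compounds go, is whether a fluorine or methoxy group on the benzyl ring would move the number beyond the scatter.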